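Cyclopropyl for Ethyl Carried into a Second Core

The compounds below may be only part of what the source reports. "The series", "measured", "known", "first", "only" and "open" are said of these compounds alone.

Compound 1 `CCCN(Cc1ccc(OCCN2C(=O)CCC2=O)c(C)c1)C(CC(=O)O)c1ccc(Cl)cc1` and compound 2 `Cc1cc(CN(CC2CC2)C(CC(=O)O)c2ccc(Cl)cc2)ccc1OCCN1C(=O)CCC1=O` share one core, while compound 3 `CCCN(Cc1ccc(OCCn2c(=O)ccn(C)c2=O)c(OC)c1)C(CC(=O)O)c1ccc(Cl)cc1` and the still unmeasured compound 4 `COc1cc(CN(CC2CC2)C(CC(=O)O)c2ccc(Cl)cc2)ccc1OCCn1c(=O)ccn(C)c1=O` share another; the difference between the two cores is not broken down here. In an ADME assay on liver (Mus musculus) for metabolic stability, read by LC-MS, using microsomes and NADPH (on this read-out higher numbers stand for a more stable compound and lower numbers for a less stable compound), compound 1 gives 75% and compound 2 gives 83%; the change between them is cyclopropyl in place of ethyl on a saturated chain carbon bound to an amine nitrogen. In this assay compound 3 gives 50%, the lowest of the three numbers, with compound 1 nearest and compound 2 furthest, both beyond the scatter. The same change, (cyclopropyl in place of ethyl on a saturated chain carbon bound to an amine nitrogen), leads from compound 3 to compound 4. Because this change earlier gave a number 8 percentage points higher from compound 1 to compound 2 (within the scatter), the new step is expected to be small as well, a number 6 percentage points higher from compound 3 to compound 4 (within the scatter). Compound 4 is therefore estimated at 56% in this assay, between 42% and 70%.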

Compound 4, percent of the compound remaining: 42%
Estimate against measurement, compound 4: 14 percentage points above; measured number inside the range.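

In this assay cyclopropyl in place of ethyl gives a number 8 percentage points lower from compound 3 to compound 4 (within the scatter), so on this core the step is no larger than the usual variation between repeats. Set beside the earlier step, the change does not carry over from one core to the other as one fixed step: the same change on two cores in this assay, a number 8 percentage points higher (within the scatter) from compound 1 to compound 2 and a number 8 percentage points lower (within the scatter) from compound 3 to compound 4, 16 percentage points apart, beyond the scatter of two such steps. Neither step alone shows a clear gain or loss, and two cores cannot show why the steps part or what the change would do on a third core.

The compounds shown leave open how other groups in that place, such as cyclobutyl or a longer chain, would behave on these two cores. They also leave open which part of the difference between the cores goes with the parting of the steps.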